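The compounds below may be only part of what the source reports. "The series", "measured", "known", "first", "only" and "open" are said of these compounds alone.

For the measured compounds named here, compound 2 `C[C@H](NC(=O)[C@]1(Cc2ccccc2)CCN1C(=O)OCc1ccccc1)C(=O)NCc1ccccc1` is one of two compounds measured in an ADME assay on HELF cells (Homo sapiens) for cytotoxicity, with a stated time of 3 days; on this read-out higher numbers stand for lower toxicity in this test and lower numbers for higher toxicity in this test. Compound 1 `C[C@H](NC(=O)[C@]1(Cc2ccccc2)CCN1C(=O)OCc1ccccc1)C(=O)NC1CCCCC1` reaches the limit of the test there, > 100000 nM, so no number was read for it. In this assay, going by the values given here, compound 2 gives 100000 nM, the only actual number among the two, and therefore the only point of reference. Among the compounds with values here, the single measured step, a number no higher from compound 1 to compound 2 (the limit leaves the size open), swaps the group on an amide-type nitrogen, but its size stays open because compound 1 sits at the limit of > 100000 nM in this assay, at which 1 of the 2 values shown sits.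

Compound 3 `C[C@H](NC(=O)[C@]1(Cc2ccccc2)CCN1C(=O)OCc1ccccc1)C(=O)N(C)C` has not been measured yet. It differs from compound 2 by dimethylamino in place of benzylamino on a carbonyl carbon. Within the data shown here, the one measured step touches the same amide-type nitrogen, yet it tells nothing about size, and both known values sit at the top of the range that this assay covers. On that basis compound 3 is expected to give about 100000 nM, with a likely range from 50000 nM to 200000 nM. The step this estimate implies, no change at the digits printed from compound 2 to compound 3 (within the scatter), is expected to lie within the scatter of the test, and a reading that again stops at the limit would not be surprising.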

Compound 3, minimum cytotoxic concentration: > 100000 nM
Compound 3 was reported as a limit (the forecaster's own chance of this, stated with the estimate: 50%); the middle value sits exactly at the limit.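

The swap to dimethylamino, with no ring and no hydrogen-bond donor, gives a number no lower from compound 2 to compound 3 (the limit leaves the size open). This carbonyl carbon has now carried a ring-free group as well as the ring-bearing groups of compound 1 and compound 2, and all three readings stay at the top of what this assay covers. No step among these compounds can be read in size, because the values gather at the top of the test: the limit of > 100000 nM in this assay, at which 2 of the 3 values shown sit.

A longer chain ending in an amine, or a carboxylic acid in place of dimethylamino, might or might not bring the reading down, and the compounds shown give no hint either way. From the compounds shown here alone, how compound 1, compound 2 and compound 3 truly rank also stays open, and settling it would take readings that do not stop at a limit.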